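Chloro for methyl on a coumarin-pyrazole pair

This account rests on a few compounds, and the source may have more. Where it says the series, first, only, none or still open, it means among the compounds named here.

Measured compounds in a functional assay on DU-145 cells (Homo sapiens) for cytotoxicity, read by MTT assay, with a stated time of 48 h; a lower number here means a stronger inhibitor, a higher number a weaker inhibitor:
compound 1, `CCOC(=O)c1c(-c2cc3cc(OC)ccc3oc2=O)nn(-c2cccc(C)c2)c1C(=O)OCC`, gives 31000 nM;
compound 2, `CCOC(=O)c1c(-c2cc3cc(OC)ccc3oc2=O)nn(-c2cccc(Cl)c2)c1C(=O)OCC`, gives 29000 nM;
compound 3, `CCOC(=O)c1c(-c2cc3ccc(OCC=C(C)C)cc3oc2=O)nn(-c2cccc(C)c2)c1C(=O)OCC`, gives 125000 nM.

Compound 1 and compound 2 share one core, while compound 3 carries a different core; the difference between the two cores is not broken down here. Compound 3 stands highest of the three numbers, its nearest neighbour being compound 1. Going by the values given here, the one counted change between compound 1 and compound 2 is chloro in place of methyl on an aromatic carbon, and it made a 1.1-fold lower number from compound 1 to compound 2 (0.03 log units; within the scatter).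

Compound 4, `CCOC(=O)c1c(-c2cc3ccc(OCC=C(C)C)cc3oc2=O)nn(-c2cccc(Cl)c2)c1C(=O)OCC`, is not yet measured. It differs from compound 3 by chloro in place of methyl on an aromatic carbon, the same change as from compound 1 to compound 2, at the same kind of place. Because the earlier step was a 1.1-fold lower number from compound 1 to compound 2 (0.03 log units; within the scatter), the step from compound 3 to compound 4 is expected to be about a 1.1-fold lower number from compound 3 to compound 4 (0.04 log units; within the scatter) in this assay. Compound 4 is therefore estimated at 115000 nM, expected to lie between 50000 nM and 260000 nM, with compound 3 as its only anchor.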

Compound 4, half-maximal inhibitory concentration: 139000 nM
Compound 4: the middle estimate sits 1.2-fold (0.08 log units) below what was measured, and the stated range covers the measured number.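

In this assay, putting chloro in place of methyl on the second core gave a 1.1-fold higher number from compound 3 to compound 4 (0.05 log units; within the scatter), so the swap from 3-methylphenyl to 3-chlorophenyl again produced no step larger than the usual scatter. Set beside the earlier step, the two cores do not differ for this change: the same change on two cores in this assay, a 1.1-fold lower number (0.03 log units; within the scatter) from compound 1 to compound 2 and a 1.1-fold higher number (0.05 log units; within the scatter) from compound 3 to compound 4, 1.2-fold (0.08 log units) apart, within the scatter of two such steps. Going by these compounds alone, this shows that, in this series, the near-absence of an effect carried from one core to the other, but it rests on only two pairs in one assay and does not show that a change with a larger effect would carry over in the same way.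

The compounds shown leave open whether a group other than methyl or chloro on this aromatic carbon, such as an amine, a methoxy group or a carboxylic acid, would move the number on either core. They also leave open whether an amide in place of the ethyl esters would change it.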